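A few compounds are considered here, and "the series" means these few. Any claim that something is new, unique, unknown or untested is made for them only; others in the source may bear on it.

In a functional assay on aorta (Rattus norvegicus, strain Sprague-Dawley) (on this read-out higher numbers stand for an effect only at larger amounts of compound and lower numbers for an effect already at smaller amounts), compound 3 `CC(=O)Nc1c(N)nc(-c2cc3c(C)nn(-c4ccccc4)c3nc2OCc2ccccc2F)nc1N` gives 930 nM with compound 2 `Cc1nn(-c2ccccc2)c2nc(OCc3ccccc3F)c(-c3nc(N)c(N(C)C)c(N)n3)cc12` at 1100 nM and compound 1 `Cc1nn(-c2ccccc2)c2nc(OCc3ccccc3F)c(-c3nc(N)cc(N)n3)cc12` at 2200 nM on the same scale. Compound 3 sits level with compound 2, as a 1.2-fold lower number from compound 2 to compound 3 (0.07 log units; within the scatter) shows, and a 2.0-fold lower number from compound 1 to compound 2 (0.30 log units; within the scatter) also stays inside the scatter. Only a 2.4-fold lower number from compound 1 to compound 3 (0.37 log units; beyond the scatter) clears it. Compound 4 `COC(=O)Nc1c(N)nc(-c2cc3c(C)nn(-c4ccccc4)c3nc2OCc2ccccc2F)nc1N` carries methoxy in place of methyl on a carbonyl carbon, so acetamido becomes (methoxycarbonyl)amino, with methoxy in place of methyl on a carbonyl carbon as the counted difference. For the measured compounds named here, no measured step makes this exact change. The largest step at the acetamido place is the modest one from compound 1, so no shift beyond the scatter is expected in this assay here. The expected step is a 1.1-fold higher number from compound 3 to compound 4 (0.03 log units; within the scatter) and no more. Compound 4 is estimated at 1000 nM with an expected range of 450 nM to 2200 nM for now.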

Compound 4, half-maximal effective concentration: 5800 nM
Beside the measured number, compound 4's estimate is 5.8-fold (0.76 log units) below it; the measured number lies above the stated range.
By their numbers in this assay, from the lowest: compounds 3, 2 and 1 (each within the scatter of the next, the first and the last beyond it); then compound 4.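

In this assay the group on the carbonyl carbon clearly matters, with a 6.2-fold higher number from compound 3 to compound 4 (0.79 log units; beyond the scatter) for methoxy in place of methyl and a 5.3-fold higher number from compound 2 to compound 4 (0.72 log units; beyond the scatter) for the swap from dimethylamino. Measured against hydrogen on the aromatic carbon, the two groups part ways, with a 2.4-fold lower number from compound 1 to compound 3 (0.37 log units; beyond the scatter) for acetamido and a 2.6-fold higher number from compound 1 to compound 4 (0.42 log units; beyond the scatter) for (methoxycarbonyl)amino, so this place can move the number in either direction. Nothing available gives a cause for this shift.

Open, going by these compounds, is whether the higher number belongs to methoxy specifically, and how ethoxy or an amine on the carbonyl carbon would read on this scale.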